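Methylamino Amide in Place of the Oxetane Amide

The source may hold more compounds than are shown below. What is called first, only, known or untested is meant among the compounds shown, and "the series" means these compounds.

Measured so far in a functional assay on CHO cells for antagonist activity at C-C chemokine receptor type 4 (Homo sapiens), read by GTPgammaS binding; on this read-out lower numbers stand for stronger inhibition and higher numbers for weaker inhibition:
compound 1, `CC(=O)NCc1cccc(Cn2nc(NS(=O)(=O)c3ccc(Cl)s3)c3ccccc32)c1`, gives 251 nM
compound 2, `CC(=O)NCc1cccc(Cn2nc(NS(=O)(=O)c3ccc(Cl)s3)c3c(F)cccc32)c1`, gives 79.4 nM
compound 3, `COc1cccc2c1c(NS(=O)(=O)c1ccc(Cl)s1)nn2Cc1cccc(CNC(=O)C2CCO2)c1`, gives 31.6 nM

Compound 3 shows the lowest number of the three measured: compound 2 lies above it beyond the scatter, and compound 1 further still. Compound 4, `CN[C@H](C)C(=O)NCc1cccc(Cn2nc(NS(=O)(=O)c3ccc(Cl)s3)c3c(OC)cccc32)c1`, differs from compound 3 by 1-(methylamino)ethyl in place of oxetan-2-yl on a carbonyl carbon. Among the compounds with values here, the only measured step, a 3.2-fold lower number from compound 1 to compound 2 (0.50 log units; beyond the scatter), concerns another part of the molecule and says nothing about the amide end. Compound 1 and compound 3 differ in two places, so their values cannot be read as a single step. With no guiding measurement, compound 4 is expected to stay close to compound 3, a 1.1-fold higher number from compound 3 to compound 4 (0.04 log units; within the scatter), with a wide range. The estimate for compound 4 is 35 nM, between 12 nM and 100 nM.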

Compound 4, half-maximal inhibitory concentration: 15.9 nM
Compound 4: the middle estimate sits 2.2-fold (0.34 log units) above what was measured; measured number inside the range.
By their numbers in this assay, from the lowest: compounds 4 and 3 (each within the scatter of the next); then compound 2; then compound 1.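

In this assay, 1-(methylamino)ethyl in place of oxetan-2-yl on the carbonyl carbon gives a 2.0-fold lower number from compound 3 to compound 4 (0.30 log units; within the scatter), so the two groups cannot be told apart here. At this position, then, the four-membered ring with its oxygen can give way to an open chain carrying a nitrogen, with no change beyond the scatter. No supporting measurement is available to explain this result. Open, from the compounds shown here alone, is how the mirror-image form of 1-(methylamino)ethyl would read. Also open, going by these compounds, is whether a longer chain, a carboxylic acid or a simple dimethylamino group on that carbonyl carbon would keep such a number.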